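The source may report more compounds than this note shows. Statements on the series, on what has been measured and on what is new or still open speak of the compounds shown alone.

Three compounds have been measured in an ADME assay on L02 cells (Homo sapiens) for cytotoxicity, read by MTT assay, with a stated time of 48 h; a lower number here means a stronger inhibitor, a higher number a weaker inhibitor:

compound 1 `COc1ccc2[nH]c(=O)c(-c3nc4ccccc4[nH]3)cc2c1`: > 100000 nM
compound 2 `COc1ccc2[nH]c(=O)c(-c3nc4cc(C)c(C)cc4[nH]3)cc2c1`: > 100000 nM
compound 3 `Cc1ccc2[nH]c(=O)c(-c3nc4cc(F)ccc4[nH]3)cc2c1`: > 100000 nM

None of these three readings is a number. For compound 1 the reading > 100000 nM is a limit of the assay. For compound 2 the reading > 100000 nM is likewise a limit. For compound 3 the reading > 100000 nM is a limit as well. For the measured compounds named here, compound 1 therefore stands where the other two stand, at the limit of > 100000 nM in this assay, at which 3 of the 3 values shown sit, and no step between any pair of measured compounds can be drawn from these readings.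

Compound 4 `COc1ccc2[nH]c(=O)c(-c3nc4cc(Br)ccc4[nH]3)cc2c1` has not yet been measured in this assay. It differs from compound 1 by bromo in place of hydrogen on an aromatic carbon. With every measured compound sitting at the same limit, and with nothing to say how a change of this kind shifts the reading, the step of a number no higher from compound 1 to compound 4 (the limit leaves the size open) is expected to be none beyond the scatter. Compound 4 is expected to give about 100000 nM in this assay, within a range from 40000 nM to 300000 nM, and most likely to be reported again only as a limit.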

Compound 4, half-maximal inhibitory concentration: > 100000 nM
Compound 4: a limit, no number; the forecaster's own chance of this, stated with the estimate: 85%; the middle value lies on the limit itself.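

For the compounds shown here, compound 4, like compound 1, gives only a limit and not a number, so no step for bromo in place of hydrogen can be read between them: the limit of > 100000 nM in this assay, at which 4 of the 4 values shown sit. The compounds shown leave open what half-maximal inhibitory concentration any of them would actually have on these cells.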